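Hydroxy to methoxy on a pyrazole urea series

This account rests on a few compounds, and the source may have more. Where it says the series, first, only, none or still open, it means among the compounds named here.

Measured compounds:
compound 1, `COc1cc(Cl)cc(-c2nn(-c3cccc(NC(=O)Nc4ccc(Cl)c(C(F)(F)F)c4)c3)cc2-c2ccncc2)c1`: -88%
compound 2, `COc1cc(Cl)cc(-c2nn(-c3cccc(NC(=O)c4cccc(C(F)(F)F)c4)c3)cc2-c2ccncc2)c1`: -14%
compound 3, `O=C(Nc1cccc(-n2cc(-c3ccncc3)c(-c3cc(O)cc(Cl)c3)n2)c1)Nc1ccc(Cl)c(Cl)c1`: -24%

In a functional assay on MDA-MB-231 cells (Homo sapiens) for inhibition, read by sulforhodamine B assay, with a stated time of 48 h, tested at 100 uM (on this read-out lower numbers stand for a stronger effect and higher numbers for a weaker effect at the one concentration tested), compound 3 sits within the scatter of compound 2 and far from compound 1, which gives a much lower number. Compound 4, `COc1cc(Cl)cc(-c2nn(-c3cccc(NC(=O)Nc4ccc(Cl)c(Cl)c4)c3)cc2-c2ccncc2)c1`, differs from compound 3 by methyl in place of hydrogen on an oxygen on an aromatic ring. For the measured compounds named here, no measured step covers this change; the only measured step, a number 74 percentage points higher from compound 1 to compound 2 (beyond the scatter), concerns a different change on the carbonyl side. Compound 1 and compound 3 differ in two places, so their values only suggest that the methoxy compound can sit much lower. Compound 4 is therefore expected to move down by a number 36 percentage points lower from compound 3 to compound 4 (beyond the scatter) in this assay, with wide uncertainty, to an estimated -60% (between -95% and -20%).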

Compound 4, a percentage reported as activity, at one concentration (the size of the read-out at that concentration, not a potency): -70%
The estimate for compound 4 lay 10 percentage points above the measured number; the range from low to high includes it.
By their numbers in this assay, from the lowest: compound 1; then compound 4; then compounds 3 and 2 (each within the scatter of the next).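

In this assay, for the compounds shown here, methyl in place of hydrogen on the oxygen gives a number 46 percentage points lower from compound 3 to compound 4 (beyond the scatter) as the first reading of this change alone. With the methoxy kept, (3,4-dichlorophenyl)amino in place of 3-(trifluoromethyl)phenyl on the carbonyl carbon gives a number 56 percentage points lower from compound 2 to compound 4 (beyond the scatter) and is a large step, whereas chloro in place of trifluoromethyl gives a number 18 percentage points higher from compound 1 to compound 4 (beyond the scatter) and is a modest one. No measurement available here accounts for these steps. Open, from the compounds shown here alone, is whether an ethoxy group or an amine in place of the methoxy would give a similar number, and whether hydroxy to methoxy gives a step of similar size with the 4-chloro-3-(trifluoromethyl)phenyl group.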